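The source may report more compounds than this note shows. Statements on the series, on what has been measured and on what is new or still open speak of the compounds shown alone.

Measured so far in a functional assay, tested at 200 ug/mL; on this read-out higher numbers stand for a stronger effect at the one concentration tested and lower numbers for a weaker effect:
compound 1 `N#CC1=C(N)OC(c2c[nH]c3ccccc23)=C(C#N)C1c1ccccc1F`: "not active" (no number reported)
compound 2 `N#CC1=C(N)OC(c2c[nH]c3ccccc23)=C(C#N)C1c1ccc(Br)cc1`: 10.6%
compound 3 `COc1ccc(C2C(C#N)=C(N)OC(c3c[nH]c4ccccc34)=C2C#N)cc1`: 26.4%

Compound 3 stands highest of the two numbers in this assay; compound 2 lies below it, and compound 1 carries no number at all. Among the compounds with values here, the only one-place step measured is a number 15.8 percentage points higher from compound 2 to compound 3 (beyond the scatter). Compound 4 `N#CC1=C(N)OC(c2c[nH]c3ccccc23)=C(C#N)C1c1cccc2ccccc12` differs from compound 3 as follows: naphthalen-1-yl in place of 4-methoxyphenyl on a saturated ring carbon. Within the data shown here, no measured step swaps one aromatic ring for another on this saturated ring carbon, so the step from compound 2 to compound 3 bears only loosely on the change; it shows that what sits on this carbon can shift the read-out by a modest amount in either direction. Compound 4 is expected to give 15% (range 0% to 35%), an expected step of a number 11.4 percentage points lower from compound 3 to compound 4 (beyond the scatter).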

Compound 4, a percentage reported as activity, at one concentration (the size of the read-out at that concentration, not a potency): 7.7%
Estimate against measurement, compound 4: 7.3 percentage points above; measured number inside the range.
By their numbers in this assay, from the lowest: compounds 4 and 2 (each within the scatter of the next); then compound 3.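

In this assay, naphthalen-1-yl on the saturated ring carbon gives a number 18.7 percentage points lower from compound 3 to compound 4 (beyond the scatter), so the larger aromatic group does not keep the read-out of 4-methoxyphenyl. Replacing 4-bromophenyl with naphthalen-1-yl gives a number 2.9 percentage points lower from compound 2 to compound 4 (within the scatter), so among the three numbers only compound 3 stands apart. Nothing measured here gives a reason for either step.

Going by these compounds, whether a hydroxyl or dimethylamino group on the phenyl ring would exceed the read-out of compound 3 stays open. So does the effect of a saturated group such as cyclohexyl on this carbon.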